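Amide substituent change: benzyl to propyl in compound 4

The source may report more compounds than this note shows. Statements on the series, on what has been measured and on what is new or still open speak of the compounds shown alone.

Measured compounds:
- compound 1 `C=CC1=C(C(=O)NCc2ccccc2)C(c2ccc(OC)c(OC)c2)OC1` gives > 100000 nM in a functional assay on A549 cells (Homo sapiens) for cytotoxicity, read by MTT assay, with a stated time of 24 h (on this read-out higher numbers stand for weaker inhibition and lower numbers for stronger inhibition), a limit of the assay.
- compound 2 `C=CC1=C(C(=O)NCc2ccccc2)C(c2ccc(OC)cc2)OC1` gives > 100000 nM, a limit of the assay.
- compound 3 `C=CC1=C(C(=O)NCCC)C(c2ccc(Cl)c(Cl)c2)OC1` gives > 100000 nM, a limit of the assay.

Compound 1 stands at a limit, not a number, and so do the two further compounds shown: all three values sit at the limit of > 100000 nM in this assay, at which 3 of the 3 values shown sit. Going by the values given here, the one single-point step among them, a step that the two limits leave unreadable from compound 1 to compound 2, cannot be read because both ends are limits.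

Compound 4 `C=CC1=C(C(=O)NCCC)C(c2ccc(OC)c(OC)c2)OC1` is compound 1 with ethyl in place of phenyl on a saturated chain carbon bound to an amide-type nitrogen. Among the compounds with values here, no measured step covers this change on the same ring. Compound 3 carries the same propylamino amide as compound 4 and sits at a limit; compound 1 with its benzylamino amide also sits at a limit. There is therefore no sign within this set that the amide substituent moves the read-out out of the limit region. The step expected for compound 4 is estimated as a step that the limit leaves unreadable from compound 1 to compound 4. Compound 4 is expected to give 200000 nM, most likely again reported only as a limit, with a range from 100000 nM to 1000000 nM.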

Compound 4, half-maximal inhibitory concentration: > 100000 nM
Compound 4: only a limit was reported; the forecaster's own chance of this, stated with the estimate: 85%; the middle value is on the limit's open side.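

Compound 1 and compound 4 both stand at a limit in this assay, so no new step can be read for benzylamino to propylamino. The compounds shown leave open whether this amide change shifts the read-out at all: the limit of > 100000 nM in this assay, at which 4 of the 4 values shown sit.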